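The source may hold more compounds than are shown below. What is called first, only, known or untested is meant among the compounds shown, and "the series" means these compounds.

Three compounds here share one core and differ in a single group. In a functional assay on M21 cells (Homo sapiens) for antiproliferative activity, read by sulforhodamine B assay, with a stated time of 48 h (a lower number here means a stronger inhibitor, a higher number a weaker inhibitor), compound 1 `O=C1NCCN1c1ccc(S(=O)(=O)Nc2cccc(Br)c2)cc1` gives 59 nM and compound 3 `O=C1NCCN1c1ccc(S(=O)(=O)Nc2cccc(Oc3ccccc3)c2)cc1` gives 83 nM; the step of a 1.4-fold higher number from compound 1 to compound 3 (0.15 log units; within the scatter) lies within the scatter. Compound 2 `CCCCOc1ccc(NS(=O)(=O)c2ccc(N3CCNC3=O)cc2)cc1` gives 580 nM, the highest of the three numbers and beyond the scatter from both of the others. Compound 4 `CCCCCCOc1ccc(NS(=O)(=O)c2ccc(N3CCNC3=O)cc2)cc1` differs from compound 2 by ethyl in place of hydrogen on a saturated chain carbon, four bonds along the chain from an oxygen on an aromatic ring. Going by the values given here, the only measured step, between bromo and phenoxy, does not lengthen a chain and so offers no guide to this change; on the evidence available a step within the scatter, in no particular direction, is expected. Compound 4 is therefore expected to give 600 nM, with a range from 200 nM to 2000 nM, corresponding to a 1.0-fold higher number from compound 2 to compound 4 (0.01 log units; within the scatter).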

Compound 4, half-maximal inhibitory concentration: > 1000 nM
Compound 4 ended at the assay's limit; the forecaster's own chance of this, stated with the estimate: 5%; at least 1.6-fold (0.22 log units) between middle value and limit.
By their numbers in this assay, from the lowest: compounds 1 and 3 (each within the scatter of the next); then compound 2. At a limit, above all of these: compound 4.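

Compound 4 has no exact number in this assay, only a limit: the limit of > 1000 nM in this assay, at which 1 of the 4 values shown sits.

Placing ethyl on this chain carbon gives an at least 1.7-fold higher number from compound 2 to compound 4 (0.23 log units; that floor lies within the scatter), so the true size of the step is unknown, and only its floor can be read. Going by these compounds alone, still, unlike the earlier compounds, this pair tests the chain itself, and the longer chain brought no lower number in this assay.

The compounds shown leave open how a propyl group, or an amine or a carboxylic acid in place of the ethyl at this position, would read.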